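Swapping an Aryl Ether for a Furan in a Piperidine Amide

The source may hold more compounds than are shown below. What is called first, only, known or untested is meant among the compounds shown, and "the series" means these compounds.

Measured compounds:
compound 1, `O=C(Nc1cccc(Oc2ccccn2)c1)C1CCCN(C(=O)c2cc(C(F)(F)F)cc(C(F)(F)F)c2)C1`, 0%
compound 2, `COCc1cccc(C(=O)N2CCCC(C(=O)Nc3ccc(Cl)cc3)C2)c1`, 0%

Both measured compounds were tested in an ADME assay on PC-3 cells (Homo sapiens) for cytotoxicity, read by WST assay, tested at 100 uM; a higher number here means more inhibition at the concentration tested (going by the name of the read-out), a lower number less inhibition. Compound 1 gives 0%, and compound 2 gives 0%. At the digits shown the two values are level, and the gap between them lies within the usual scatter of repeated measurements, so neither compound can be said to stand above the other. Compound 1 therefore sits with compound 2 at the bottom of the scale, showing no measurable effect on the cells at the tested concentration.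

Going by the values given here, the new compound, compound 3, `O=C(Nc1cccc(-c2ccco2)c1)C1CCCN(C(=O)c2cc(C(F)(F)F)cc(C(F)(F)F)c2)C1`, keeps the whole core of compound 1 and changes only one group on the aromatic ring. The difference is furan-2-yl in place of (pyridin-2-yl)oxy on an aromatic carbon.

Among the compounds with values here, no pair of measured compounds differing in a single place is available to show how large such a change usually moves the read-out in this assay. Given that compound 1 shows 0% and compound 2 shows 0%, the expectation is that the step from compound 1 to compound 3 stays within the scatter, a number 4 percentage points higher from compound 1 to compound 3 (within the scatter). Compound 3 is therefore estimated at 4%, with a range from 0% to 20%.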

Compound 3, a percentage reported as inhibition, at one concentration (the size of the read-out at that concentration, not a potency): 0%
Compound 3: middle estimate off by 4 percentage points, on the high side; the measured number falls inside the stated range.
By their numbers in this assay, from the lowest: compounds 1, 2 and 3 (each within the scatter of the next).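

In this assay, going by these compounds alone, putting furan-2-yl in place of (pyridin-2-yl)oxy, on an aromatic carbon meta to a large group, brings no change at the digits printed from compound 1 to compound 3 (within the scatter), and this is the first look at a change made in one place only. A six-membered aromatic ring gives way to a smaller five-membered one with the rest of the molecule held constant, and the cells show no measurable difference, so neither group stands out at this position in this read-out. No measurement at hand explains this outcome, and with both values at the bottom of the scale, the step cannot show whether either group would matter in a compound with a measurable effect.

On these data alone, it remains open whether any group at this position can raise the reading above the bottom of the scale, for example a basic amine such as aminomethyl, a carboxylic acid, or a longer chain such as butoxy. As far as these compounds go, it also remains open whether the same swap would stay silent on a core that does affect these cells.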